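This account rests on a few compounds, and the source may have more. Where it says the series, first, only, none or still open, it means among the compounds named here.

Of the compounds shown here, two with the same core have been measured so far. In a physicochemical assay for solubility, measured as kinetic solubility (a lower number here means a less soluble compound, a higher number a more soluble compound), compound 1 `O=C(N[C@@H](CO)c1cccc(Cl)c1)[C@H]1CC(F)(F)CC[C@@H]1c1ccccc1`, which carries a chloro group on an aromatic carbon, gives 318000 nM. Compound 2 `O=C(N[C@@H](CO)c1ccccc1)[C@H]1CC(F)(F)CC[C@@H]1c1ccccc1`, with hydrogen on that carbon, gives 332000 nM. Among the measured compounds shown here, these two numbers are level within the scatter, so compound 2 stands no clear distance from its only measured neighbour.

The next structure, compound 3 `O=C(N[C@@H](CO)c1cccc(C(F)(F)F)c1)[C@H]1CC(F)(F)CC[C@@H]1c1ccccc1`, is compound 2 with trifluoromethyl in place of hydrogen on an aromatic carbon, meta to a large group: trifluoromethyl in place of hydrogen on an aromatic carbon. For the measured compounds named here, only one measured step bears on this change, the exchange of chloro for hydrogen on an aromatic carbon, and it was a 1.0-fold higher number from compound 1 to compound 2 (0.02 log units; within the scatter). Going by the values given here, no measured compound carries trifluoromethyl, so this single step is only a loose guide.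

What is expected in this assay is therefore no change beyond the scatter, with an estimated 1.3-fold lower number from compound 2 to compound 3 (0.11 log units; within the scatter). For compound 3 the estimated value is 260000 nM, with an expected range from 110000 nM to 400000 nM.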

Compound 3, solubility: 119000 nM
Compound 3: middle estimate off by 2.2-fold (0.34 log units), on the high side; low and high end bracket the measured number.
By their numbers in this assay, from the lowest: compound 3; then compounds 1 and 2 (each within the scatter of the next).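

In this assay the carbon that carries the new group is no longer silent: the exchange of chloro for hydrogen had stayed within the scatter at a 1.0-fold higher number from compound 1 to compound 2 (0.02 log units; within the scatter) but trifluoromethyl in place of hydrogen gives a 2.8-fold lower number from compound 2 to compound 3 (0.45 log units; beyond the scatter) and this step lies beyond it. Trifluoromethyl also parts from chloro on the same carbon, at a 2.7-fold lower number from compound 1 to compound 3 (0.43 log units; beyond the scatter) so that compound 3 stands lowest of the three, while compound 1 and compound 2 remain level with each other, and the earlier step could not have shown that the group placed here can matter in this read-out. Nothing measured alongside these numbers explains why trifluoromethyl behaves differently from chloro here.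

On these data alone, with only hydrogen, chloro and trifluoromethyl at this carbon, it remains open where other groups, such as a nitrile, a methoxy group, an amine or a carboxylic acid, would fall on this scale. As far as these compounds go, it is also open whether trifluoromethyl would give a step of similar size on another carbon of this ring, or with the rest of the shared core changed.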